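Methoxy in place of hydrogen: a second position

This account rests on a few compounds, and the source may have more. Where it says the series, first, only, none or still open, it means among the compounds named here.

Compound 1 `Cn1nnnc1SCC(=O)N/N=C/c1ccccc1` gives 3160000 nM in a functional assay on A549 cells (Homo sapiens) for cytotoxicity, read by XTT assay, with a stated time of 24 h; on this read-out higher numbers stand for weaker inhibition and lower numbers for stronger inhibition. On the numbers shown, compound 1 holds the only numerical value in this assay, the one further result being a limit rather than a number. Compound 2 `COc1ccc(/C=N/NC(=O)CSc2nnnn2C)cc1` reaches only the limit > 10000000 nM in this assay. Placing a methoxy in place of hydrogen on an aromatic carbon gives an at least 3.1-fold higher number from compound 1 to compound 2 (0.50 log units; beyond the scatter), and this reads as a limit of the assay, consistent with the limit of > 10000000 nM in this assay, at which 1 of the 2 values shown sits.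

Compound 3 `COc1cccc(/C=N/NC(=O)CSc2nnnn2C)c1` differs from compound 1 by methoxy in place of hydrogen on an aromatic carbon. Within the data shown here, the one measured step that bears on this is the addition of the same group on the same ring of compound 1, which gave a weakening that was at least modest and beyond the scatter. The expectation is therefore a weaker inhibition, a higher number in this assay, of a size that may again run up to the limit rather than a number. The step from compound 1 to compound 3 is estimated as a 2.5-fold higher number from compound 1 to compound 3 (0.40 log units; beyond the scatter). Compound 3 is expected to give 8000000 nM, with a range from 3000000 nM to 30000000 nM.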

Compound 3, half-maximal inhibitory concentration: > 10000000 nM
Compound 3 ended at the assay's limit (the forecaster's own chance of this, stated with the estimate: 45%); middle value at least 1.2-fold (0.09 log units) away from the limit.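

In this assay, methoxy in place of hydrogen on an aromatic carbon, here meta to a large group, gives an at least 3.1-fold higher number from compound 1 to compound 3 (0.50 log units; beyond the scatter), so the weakening seen with compound 2 is not tied to a single place on the ring. As far as these compounds go, for compound 3, > 10000000 nM is a limit of the assay and not a number, so this step fixes only a minimum size and its true size stays unknown. The two placements of the methoxy cannot be ranked against each other because compound 2 and compound 3 both end at the same limit: the limit of > 10000000 nM in this assay, at which 2 of the 3 values shown sit.

Among these compounds, with compound 1, at 3160000 nM, still the only compound holding a number, the series shows no change that gives a lower number than the unsubstituted ring. Open, from the compounds shown here alone, is whether an amine or a carboxylic acid in place of the methoxy, or a longer chain on the oxygen such as ethoxy, would stay within reach of a number or would also run to the limit.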